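Aryl swap on the core of compound 1: compound 3

The source may report more compounds than this note shows. Statements on the series, on what has been measured and on what is new or still open speak of the compounds shown alone.

Measured so far in an in vitro functional assay on HEK285-7 cells for antagonist activity at prostaglandin D2 receptor 2 (Homo sapiens), read by BRET and beta-arrestin recruitment; on this read-out lower numbers stand for smaller maximal responses and higher numbers for larger maximal responses:
compound 1 `O=C(O)Cc1sc(C(c2ccc(F)cc2)c2ccc(F)cc2)nc1-c1ccc(Cl)cc1` — 80%
compound 2 `O=C(O)Cc1sc(CSc2ccccc2)nc1-c1ccc(Cl)cc1` — 50%

Compound 1 holds the higher of the two numbers in this assay; compound 2 sits lower by a gap that is beyond the scatter, so compound 1 stands clearly on top of what has been measured. Among the measured compounds shown here, the two compounds differ in more than one place, and no step between compounds differing in a single place is available, so the weight of any one change on the core of compound 1 cannot be read from the data.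

Compound 3 `O=C(O)Cc1sc(C(c2ccc(F)cc2)c2ccc(F)cc2)nc1-c1cc(F)cc(F)c1` is not yet measured. It differs from compound 1 by 3,5-difluorophenyl in place of 4-chlorophenyl on an aromatic carbon. For the measured compounds named here, with no comparable step measured, a small downward step is expected: the step of a number 10 percentage points lower from compound 1 to compound 3 (within the scatter) is the estimate, and it may still fall within the scatter. Compound 3 is expected to give 70%, with a range from 45% to 95%.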

Compound 3, largest response reached (reported as efficacy), in percent of the reference or control that the assay uses: 80%
Beside the measured number, compound 3's estimate is 10 percentage points below it, and the stated range covers the measured number.
By their numbers in this assay, from the lowest: compound 2; then compounds 1 and 3 (each within the scatter of the next).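

In this assay, 3,5-difluorophenyl in place of 4-chlorophenyl, on the aromatic carbon next to the ring nitrogen, gives no change at the digits printed from compound 1 to compound 3 (within the scatter). Among the compounds shown here, this is the only single-place step on the core of compound 1, and it shows that this position accepts the two aryl groups without separating them on this read-out, a finding that holds for this pair alone. No information is available that would explain this result.

On these data alone, whether the position also accepts an aryl group bearing an amine or a methoxy group, or a pyridine ring in place of the phenyl, remains open. Compound 2 differs from compound 1 and compound 3 in more than one place, so steps involving compound 2 cannot be read.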